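A few compounds are considered here, and "the series" means these few. Any claim that something is new, unique, unknown or untested is made for them only; others in the source may bear on it.

The measured compounds in a functional assay on HL-60 cells (Homo sapiens) for cytotoxicity, read by MTT assay, with a stated time of 48 h; on this read-out lower numbers stand for stronger inhibition and higher numbers for weaker inhibition:

Compound 1 `Fc1ccc(Nc2nc(-c3cccc(F)c3)nc3ccc(F)cc23)cc1` sits at a limit of this assay, > 50000 nM.
Compound 2 `Fc1cccc(-c2nc(Nc3ccc(Cl)cc3)c3cc(F)ccc3n2)c1` gives 45700 nM.
Compound 3 `Fc1cccc(-c2nc(Nc3ccccc3Br)c3cc(F)ccc3n2)c1` sits at a limit of this assay, > 50000 nM.

For the measured compounds named here, compound 2 is the only one with a real number; the other two stand at the limit of > 50000 nM in this assay, at which 2 of the 3 values shown sit. The step of an at least 1.0-fold lower number from compound 1 to compound 2 (0.03 log units; that floor lies within the scatter), and the step of an at least 1.0-fold higher number from compound 2 to compound 3 (0.03 log units; that floor lies within the scatter); neither reads as a change beyond the scatter. Compound 4 `Cc1cccc(Nc2nc(-c3cccc(F)c3)nc3ccc(F)cc23)c1` is the next compound, differing from compound 2 by 3-methylphenyl in place of 4-chlorophenyl on a nitrogen on an aromatic ring. Both measured steps swap one ring on that nitrogen, or a halogen on it, for another and move nothing readable, so no step beyond the scatter is expected here. Compound 4 is therefore estimated at 50000 nM, ranging from 25000 nM to 100000 nM, an expected step of a 1.1-fold higher number from compound 2 to compound 4 (0.04 log units; within the scatter), quite possibly reported only as a limit.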

Compound 4, half-maximal inhibitory concentration: > 50000 nM
Compound 4 ended at the assay's limit; the forecaster's own chance of this, stated with the estimate: 55%; the middle value sits exactly at the limit.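

In this assay, 3-methylphenyl brings a ring without halogen onto the nitrogen, and the result is an at least 1.0-fold higher number from compound 2 to compound 4 (0.03 log units; that floor lies within the scatter). Compound 4 gives > 50000 nM, which is a limit of the assay and not a number, so its steps from compound 1 and compound 3 cannot be read. A methyl-bearing ring thus lands where two of the halogen-bearing rings did: the limit of > 50000 nM in this assay, at which 3 of the 4 values shown sit.

On these data alone, whether an amine or a carboxylic acid on that ring, or a longer chain in its place, would give a readable number in this assay stays open. So does the effect of any change to the shared core.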